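Compound 3 to compound 4: a larger amine on the carbonyl

The source may report more compounds than this note shows. Statements on the series, on what has been measured and on what is new or still open speak of the compounds shown alone.

Compounds measured in a functional assay on A2780 cells (Homo sapiens) for antiproliferative activity (on this read-out higher numbers stand for weaker inhibition and lower numbers for stronger inhibition), so far:
- compound 1 `CCN1Cc2c(ccc(C)c2C)C(c2ccccc2)C1` gives 5300 nM
- compound 2 `Cc1ccc2c(c1C)CN(S(C)(=O)=O)CC2c1ccccc1` gives "not determined" (no result reported)
- compound 3 `Cc1ccc2c(c1C)CN(C(=O)N(C)C)CC2c1ccccc1` gives 1200 nM

Compound 3 has the lower of the two numbers available, and compound 2 offers no number for comparison. Compound 4 `Cc1ccc2c(c1C)CN(C(=O)N1CCCCC1)CC2c1ccccc1` has not yet been measured. It differs from compound 3 by piperidin-1-yl in place of dimethylamino on a carbonyl carbon and so carries piperidin-1-yl in place of dimethylamino on a carbonyl carbon.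

For the measured compounds named here, only one measured step bears on this change, and only indirectly. It is the modest 4.4-fold lower number from compound 1 to compound 3 (0.65 log units; beyond the scatter) for dimethylcarbamoyl in place of ethyl on an amine nitrogen in a ring. That step introduced the carbonyl group, whereas compound 4 keeps it and alters only the amine attached to it. Going by the values given here, no measured step shows what such an exchange does. A change beyond the usual scatter is therefore not expected in either direction. The estimate is a 1.2-fold lower number from compound 3 to compound 4 (0.08 log units; within the scatter) and this expected step remains small. For compound 4 the estimate in this assay is 1000 nM (expected range 350 nM to 3000 nM).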

Compound 4, half-maximal inhibitory concentration: 2830 nM
The estimate for compound 4 lay 2.8-fold (0.45 log units) below the measured number; measured number inside the range.
By their numbers in this assay, from the lowest: compound 3; then compounds 4 and 1 (each within the scatter of the next).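

In this assay, the amine on the carbonyl carbon turns out to matter: piperidin-1-yl in place of dimethylamino gives a measurable step (a 2.4-fold higher number from compound 3 to compound 4 (0.37 log units; beyond the scatter)), so the gain seen with dimethylcarbamoyl does not carry over in full to this larger group. Having a carbonyl on the ring nitrogen is therefore not enough on its own, since (piperidin-1-yl)carbonyl in place of ethyl leaves the two compounds within the scatter of each other (a 1.9-fold lower number from compound 1 to compound 4 (0.27 log units; within the scatter)). No measurement at hand accounts for the difference between these amines.

The compounds shown leave open whether a pyrrolidin-1-yl or morpholin-4-yl group on the carbonyl would stand with dimethylamino or with piperidin-1-yl. They also leave open what methylamino, with its remaining hydrogen on the nitrogen, would do at this place.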